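From phenyl to 4-methylphenyl in compound 2

The compounds below may be only part of what the source reports. "The series", "measured", "known", "first", "only" and "open" are said of these compounds alone.

In a physicochemical assay for lipophilicity (a higher number here means a more lipophilic compound, a lower number a more polar compound), compound 1 (`O=C1/C(=C/c2ccc(F)cc2)CCC/C1=C\c1cccc([N+](=O)[O-])c1`) gives 5.07 and compound 2 (`O=C1/C(=C/c2ccccc2)CCC/C1=C\c1ccc([N+](=O)[O-])cc1`) gives 4.93 as its value, so these two stand within the scatter of each other. Compound 3 (`Cc1ccc(/C=C2\CCC/C(=C\c3ccc([N+](=O)[O-])cc3)C2=O)cc1`) awaits measurement. It carries methyl in place of hydrogen on an aromatic carbon of compound 2 (methyl in place of hydrogen on an aromatic carbon), para to a large group. Among the measured compounds shown here, no measured pair shows this change, so the expectation rests on the structural change alone. The expected step of a number 0.45 log units higher from compound 2 to compound 3 (beyond the scatter) is a modest rise in this assay that should lie just beyond the scatter. Compound 3 is estimated at 5.38 with an expected range of 5.05 to 5.75 in this series.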

Compound 3, partition coefficient: 5.38
For compound 3 middle estimate and measured number coincide at the digits printed; low and high end bracket the measured number.
By their numbers in this assay, from the lowest: compounds 2 and 1 (each within the scatter of the next); then compound 3.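

In this assay the series now has its first step between compounds that differ in one place: a number 0.45 log units higher from compound 2 to compound 3 (beyond the scatter), beyond the scatter. Methyl in place of hydrogen on an aromatic carbon, para to a large group, therefore registers in this assay, though this reading rests on a single pair. As far as these compounds go, whether an ethyl chain, an amine or a carboxylic acid at the same place would shift the number in the same direction stays open, as does any reading of the step in the other ring of the shared core. Nothing at hand accounts for the size of this step.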